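Trimming a Chain and Watching Cell Tolerance

This account rests on a few compounds, and the source may have more. Where it says the series, first, only, none or still open, it means among the compounds named here.

Compound 1 `CCCCCCNc1cncc(C(=O)NCc2ccccc2)n1`: 100000 nM
Compound 2 `CCCCNc1nccnc1C(=O)NCc1ccccc1`: > 100000 nM

Both compounds were tested in an ADME assay on Vero cells (Chlorocebus sabaeus) for cytotoxicity, read by microscopy, with a stated time of 6 days; a higher number here means that more compound is tolerated, a lower number that less compound is tolerated. For the measured compounds named here, compound 1 gives 100000 nM, the only outright number among the two values. For compound 2 the result is a limit of the assay, > 100000 nM. That reading is the limit of > 100000 nM in this assay, at which 1 of the 2 values shown sits. Compound 3 `CCCCNc1cncc(C(=O)NCc2ccccc2)n1` arises from compound 1 through the change (hydrogen in place of ethyl on a saturated chain carbon, four bonds along the chain from a nitrogen on an aromatic ring). Going by the values given here, no pair of measured compounds differs in a single place, so no measured step guides this one. In this assay the step of no change at the digits printed from compound 1 to compound 3 (within the scatter) is expected to be small, toward more tolerated or none beyond the scatter. Compound 3 is therefore estimated at 100000 nM, between 50000 nM and 200000 nM, quite possibly reported only as a limit.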

Compound 3, minimum cytotoxic concentration: 100000 nM
Compound 3: the middle estimate sits on the measured number at the digits printed, within the range that was stated.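

In this assay, putting hydrogen in place of ethyl on the saturated chain carbon, four bonds along the chain from a nitrogen on an aromatic ring, gives no change at the digits printed from compound 1 to compound 3 (within the scatter). For the compounds shown here, this is the first measured step that differs in one place, and it shows that in this pair the end of the chain can go without a visible shift in cell tolerance. The flat step may say little, however, because these readings lie close to what the assay can report: the limit of > 100000 nM in this assay, at which 1 of the 3 values shown sits.

On these data alone, whether a longer chain would lower the tolerated concentration remains open. So does the effect of an amine or a carboxylic acid at the end of the chain.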